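Swapping a 4-chlorophenyl for a vinyl on the shared core

The source may hold more compounds than are shown below. What is called first, only, known or untested is meant among the compounds shown, and "the series" means these compounds.

Measured so far:
- compound 1, `Cc1nc(-c2c[nH]c3ccccc23)co1`, 689000 nM
- compound 2, `c1ccc2c(-c3coc(-c4ccncc4)n3)c[nH]c2c1`, 38400 nM
- compound 3, `Clc1ccc(-c2nc(-c3c[nH]c4ccccc34)co2)cc1`, 326000 nM

All three numbers come from a functional assay on MIA PaCa-2 cells (Homo sapiens) for cytotoxicity, read by MTT assay, with a stated time of 48 h; a lower number here means a stronger inhibitor, a higher number a weaker inhibitor. Compound 3 stands second highest of the three: compound 1 sits nearest to it, with a step of a 2.1-fold lower number from compound 1 to compound 3 (0.33 log units; beyond the scatter), while compound 2 sits furthest, with an 8.5-fold higher number from compound 2 to compound 3 (0.93 log units; beyond the scatter).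

Compound 4, `C=Cc1nc(-c2c[nH]c3ccccc23)co1`, differs from compound 3 in one place: vinyl in place of 4-chlorophenyl on an aromatic carbon. Among the compounds with values here, no measured step swaps the 4-chlorophenyl for a vinyl, so the closest guides are the steps that put a small group against a ring. From compound 1 to compound 3, replacing methyl with 4-chlorophenyl gave a 2.1-fold lower number from compound 1 to compound 3 (0.33 log units; beyond the scatter), and from compound 1 to compound 2, replacing methyl with pyridin-4-yl gave an 18-fold lower number from compound 1 to compound 2 (1.25 log units; beyond the scatter). A vinyl is small like a methyl, so compound 4 is expected to land close to compound 1, which means a modest rise from compound 3, a 1.7-fold higher number from compound 3 to compound 4 (0.23 log units; within the scatter). Compound 4 is therefore estimated at 550000 nM, within the range 200000 nM to 1500000 nM.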

Compound 4, half-maximal inhibitory concentration: 37600 nM
Beside the measured number, compound 4's estimate is 15-fold (1.17 log units) above it; measured number outside the range, below it.
By their numbers in this assay, from the lowest: compounds 4 and 2 (each within the scatter of the next); then compound 3; then compound 1.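

In this assay, the small vinyl on this carbon of the five-membered ring does not behave like the small methyl, as an 18-fold lower number from compound 1 to compound 4 (1.26 log units; beyond the scatter) shows, so small size alone does not set the number here. Replacing the 4-chlorophenyl also helps, with an 8.7-fold lower number from compound 3 to compound 4 (0.94 log units; beyond the scatter) for the vinyl, while a 1.0-fold lower number from compound 2 to compound 4 (0.01 log units; within the scatter) puts compound 4 within the scatter of compound 2, so a group with no ring can match the pyridin-4-yl and a ring is not needed for a number of this size. No measurement shown here explains these differences.

As far as these compounds go, how an ethyl group, which has no double bond outside aromatic rings, would compare with the vinyl stays open. So does the effect of an amine or a carboxylic acid on this carbon.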